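Compound 4: 3-nitrophenyl in place of 3,4-dichlorophenyl

The source may report more compounds than this note shows. Statements on the series, on what has been measured and on what is new or still open speak of the compounds shown alone.

In a functional assay on HeLa cells (Homo sapiens) for cytotoxicity, read by MTT assay, with a stated time of 24 h (a lower number here means a stronger inhibitor, a higher number a weaker inhibitor), compound 1 `COc1cc(/C=C2\CN(C)C/C(=C\c3cc(OC)c(OC)c(OC)c3)C2=O)cc(OC)c1` gives 2300 nM, compound 2 `COc1cc(/C=C2\CN(C)C/C(=C\c3ccc(F)cc3)C2=O)cc(OC)c1OC` gives 7250 nM and compound 3 `COc1cc(/C=C2\CN(C)C/C(=C\c3ccc(Cl)c(Cl)c3)C2=O)cc(OC)c1OC` gives 13500 nM. Compound 3 stands at the high-number end of the series, but not alone: the nearest measured step is a 1.9-fold higher number from compound 2 to compound 3 (0.27 log units; within the scatter), while the furthest is a 5.9-fold higher number from compound 1 to compound 3 (0.77 log units; beyond the scatter).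

Compound 4 `COc1cc(/C=C2\CN(C)C/C(=C\c3cccc([N+](=O)[O-])c3)C2=O)cc(OC)c1OC` keeps the shared core and carries 3-nitrophenyl in place of 3,4-dichlorophenyl on a double-bonded chain carbon bound to a double-bonded ring carbon.

Going by the values given here, no compound with a 3-nitrophenyl group has been measured, so no step speaks directly to this group. Among the compounds with values here, the only guide is the spread of changes at this place, which also includes a 3.2-fold higher number from compound 1 to compound 2 (0.50 log units; beyond the scatter). These steps are modest. With compound 3 at the high end of that spread, a modest move towards a lower number is expected, though the evidence is thin. The expected step is a 2.1-fold lower number from compound 3 to compound 4 (0.32 log units; beyond the scatter). For compound 4 the estimated value is 6500 nM, with an expected range of 2200 nM to 16000 nM.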

Compound 4, half-maximal inhibitory concentration: 5540 nM
Beside the measured number, compound 4's estimate is 1.2-fold (0.07 log units) above it; the range from low to high includes it.
By their numbers in this assay, from the lowest: compound 1; then compounds 4, 2 and 3 (each within the scatter of the next, the first and the last beyond it).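

Exchanging 3,4-dichlorophenyl for 3-nitrophenyl at this place in this assay gives a 2.4-fold lower number from compound 3 to compound 4 (0.39 log units; beyond the scatter) and brings the series its first aryl group with nitrogen and oxygen atoms, while exchanging 4-fluorophenyl for it gives a 1.3-fold lower number from compound 2 to compound 4 (0.12 log units; within the scatter) so compounds 2 and 4 cannot be told apart here. The 3,5-dimethoxyphenyl group still sets the low end of the series, with a 2.4-fold higher number from compound 1 to compound 4 (0.38 log units; beyond the scatter) as the exchange to 3-nitrophenyl. No measured evidence is available to explain these differences.

Still open, as far as these compounds go, is whether this place accepts a group without an aromatic ring, such as an amine or a carboxylic acid on a longer chain. Also open is whether the order seen among these four compounds holds in any other cell line.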